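Hydroxy for chloro on the benzamide of compound 1

The compounds below may be only part of what the source reports. "The series", "measured", "known", "first", "only" and "open" are said of these compounds alone.

Measured compounds:
compound 1 `COc1cccc(C(=O)NCc2c(C)cc(C)[nH]c2=O)c1Cl` with 7200 nM in an assay on Sf9 cells for inhibition of histone-lysine N-methyltransferase EZH2 (Homo sapiens), read by scintillation counting, with a stated time of 60 min, in the presence of a further agent that is not named here; on this read-out higher numbers stand for weaker inhibition and lower numbers for stronger inhibition
compound 2 `Cc1cc(C)c(CNC(=O)c2cccc(OC(C)C)c2Cl)c(=O)[nH]1` with 1300 nM

Within the data shown here, compound 1 gives the highest of the two numbers in this assay; the only step known, a 5.5-fold lower number from compound 1 to compound 2 (0.74 log units; beyond the scatter), concerns the alkoxy group and not the position changed here. Compound 3 `COc1cccc(C(=O)NCc2c(C)cc(C)[nH]c2=O)c1O` carries the change (hydroxy in place of chloro on an aromatic carbon). Among the measured compounds shown here, no measured step bears on this exchange, so compound 3 is expected to stay close to compound 1, with a step of a 1.4-fold higher number from compound 1 to compound 3 (0.14 log units; within the scatter) that is expected to lie within the scatter. The estimate for compound 3 is 10000 nM, with a range from 3000 nM to 35000 nM.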

Compound 3, half-maximal inhibitory concentration: 44000 nM
For compound 3 the middle estimate is 4.4-fold (0.64 log units) below the measured one; the measured number lies above the stated range.
By their numbers in this assay, from the lowest: compound 2; then compound 1; then compound 3.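

Among these compounds, at the position ortho to a methoxy group, the group present clearly matters: hydroxy in place of chloro gives a 6.1-fold higher number from compound 1 to compound 3 (0.79 log units; beyond the scatter) and is the first exchange seen at this position. The earlier pair varied only the alkoxy group and showed nothing about this place. No evidence at hand accounts for this step.

Going by these compounds, whether chloro itself is needed stays open, since only hydroxy has replaced it; bromo, methyl or an amine at this position would test that. Also open, on these data alone, is whether hydroxy here would give a similar step with the isopropyl ether of compound 2.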